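This account rests on a few compounds, and the source may have more. Where it says the series, first, only, none or still open, it means among the compounds named here.

In a functional assay on MGC-803 cells (Homo sapiens) for inhibition, read by MTT assay, with a stated time of 72 h (a lower number here means a stronger inhibitor, a higher number a weaker inhibitor), compound 3 `Cc1ccc(-n2cc(CNC(=O)c3cccc4c3cnn4C(C)C)nn2)cc1` gives > 40000 nM, which is a limit of the assay rather than a measured number. Compound 1 `Cc1ccc(-n2cc(CNC(=O)c3cccc4c3cnn4C(C)C)nn2)c(C)c1` likewise gives > 40000 nM, again only a limit. Compound 2 `CC(C)n1ncc2c(C(=O)NCc3cn(-c4ccc([N+](=O)[O-])cc4)nn3)cccc21` gives > 40000 nM, also a limit. Because all three values sit at the limit of > 40000 nM in this assay, at which 3 of the 3 values shown sit, the steps a step that the two limits leave unreadable from compound 1 to compound 3, a step that the two limits leave unreadable from compound 1 to compound 2 and a step that the two limits leave unreadable from compound 2 to compound 3 cannot be read in size. Compound 4 `Cc1ccccc1-n1cc(CNC(=O)c2cccc3c2cnn3C(C)C)nn1` differs from compound 3 by 2-methylphenyl in place of 4-methylphenyl on an aromatic nitrogen. For the measured compounds named here, since none of the measured steps has a readable size, no step beyond the scatter is expected in this assay, and the result is expected to remain at the limit. Compound 4 is therefore estimated at 40000 nM, within 20000 nM to 100000 nM, an expected step of a number no higher from compound 3 to compound 4 (the limit leaves the size open).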

Compound 4, half-maximal inhibitory concentration: > 40000 nM
Compound 4: no number, only a limit; the forecaster's own chance of this, stated with the estimate: 85%; the middle value lies on the limit itself.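

Compound 4 gives > 40000 nM as a limit of the assay, so its steps from compound 1, compound 2 and compound 3 cannot be read in size: the limit of > 40000 nM in this assay, at which 4 of the 4 values shown sit.

The compounds shown leave open how strongly any of them acts in this assay and whether changing the group on the aromatic nitrogen alters that strength at all.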